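A few compounds are considered here, and "the series" means these few. Any claim that something is new, unique, unknown or untested is made for them only; others in the source may bear on it.

In an ADME assay on HepG2 cells (Homo sapiens) for cytotoxicity, read by XTT assay, with a stated time of 2 days (on this read-out lower numbers stand for higher toxicity in this test and higher numbers for lower toxicity in this test), compound 1 `Cc1cc(NC(=O)c2sc(N)c(C(N)=O)c2C)ccc1Cl` gives > 100000 nM, which is a limit of the test rather than a measured number. Compound 2 `Cc1c(C(=O)Nc2ccc(F)c(C(F)(F)F)c2)sc(N)c1C(N)=O` likewise gives > 100000 nM in this assay, again a limit and not a number. Compound 2 thus stands at the limit of > 100000 nM in this assay, at which 2 of the 2 values shown sit, and no step between measured compounds is shown, so the numbers give no direction to work from. Compound 3 `Cc1c(C(=O)Nc2ccc(Cl)c(C(F)(F)F)c2)sc(N)c1C(N)=O` differs from compound 2 by chloro in place of fluoro on an aromatic carbon. With both measured values sitting at the limit, the expected step from compound 2 to compound 3 in this assay is a step that the limit leaves unreadable from compound 2 to compound 3, none beyond the scatter in either direction. Compound 3 is therefore estimated at 110000 nM in this assay, with a range from 40000 nM to 300000 nM, and the test is expected most often to report only a limit again.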

Compound 3, half-maximal cytotoxic concentration: 72000 nM
Estimate against measurement, compound 3: 1.5-fold (0.18 log units) above; the range from low to high includes it.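

Among these compounds, compound 3 is the first compound here to give a number rather than a limit in this assay, so the position para to a large group and ortho to a trifluoromethyl group now has a first reading for chloro in place of fluoro: an at least 1.3-fold lower number from compound 2 to compound 3 (0.14 log units; that floor lies within the scatter). Trifluoromethyl in place of methyl on an aromatic carbon can now be read in the same way: an at least 1.3-fold lower number from compound 1 to compound 3 (0.14 log units; that floor lies within the scatter). Both steps are only floors within the scatter, so neither shows a real change, and both start from a limit rather than a number: the limit of > 100000 nM in this assay, at which 2 of the 3 values shown sit.

On these data alone, the true distance of compound 1 and compound 2 from compound 3 remains open. Also open, as far as these compounds go, is whether another group at this position, such as a bromo, a methoxy group or an amine, would give a clearly lower number.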